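This account rests on a few compounds, and the source may have more. Where it says the series, first, only, none or still open, it means among the compounds named here.

Compound 1, `COc1cc(COC(c2ccc(OC)c(OC)c2OC)c2cccc3ccccc23)cc(OC)c1`, in a functional assay on MCF7 cells (Homo sapiens) for inhibition, read by sulforhodamine B assay, with a stated time of 48 h; on this read-out lower numbers stand for stronger inhibition and higher numbers for weaker inhibition: > 20000 nM, which is a limit of the assay and not a number.
Compound 2, `COc1ccc(C(O)(C/C=C\c2ccccc2)c2cccc3ccccc23)c(OC)c1OC`: 10200 nM.
Compound 3, `COc1ccc(C(OCc2ccccc2)c2cccc3ccccc23)c(OC)c1OC`: 14100 nM.

Among the measured compounds, compound 3 carries the highest of the two numbers in this assay; its nearest neighbour is compound 2, and the gap between the two lies within the scatter. Among the measured compounds shown here, the only single-point step among the measured compounds is an at least 1.4-fold lower number from compound 1 to compound 3 (0.15 log units; that floor lies within the scatter), and its floor lies within the scatter, with the limit of > 20000 nM in this assay, at which 1 of the 3 values shown sits, fixing the starting value of that step.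

Compound 4, `COc1ccc(C(c2ccc(O)cc2)c2cccc3ccccc23)c(OC)c1OC`, has not yet been measured. It differs from compound 3 by 4-hydroxyphenyl in place of benzyloxy on a saturated chain carbon bound to two aromatic carbons. For the measured compounds named here, no measured step changes this position of the shared core, so the measured steps give no direct guide to the size or direction of the change from compound 3 to compound 4 in this assay. The account therefore rests on compound 3 alone, and the expectation is for an estimated step of a 2.4-fold lower number from compound 3 to compound 4 (0.37 log units; beyond the scatter). Compound 4 is expected to give about 6000 nM, with a range from 900 nM to 25000 nM.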

Compound 4, half-maximal inhibitory concentration: 17500 nM
The estimate for compound 4 lay 2.9-fold (0.46 log units) below the measured number; low and high end bracket the measured number.
By their numbers in this assay, from the lowest: compounds 2, 3 and 4 (each within the scatter of the next). At a limit, above all of these: compound 1.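

In this assay, placing 4-hydroxyphenyl in place of benzyloxy on a saturated chain carbon bound to two aromatic carbons gives a 1.2-fold higher number from compound 3 to compound 4 (0.09 log units; within the scatter). Among the compounds shown here, this is the first reading at this position, since the only earlier step concerned phenyl in place of 3,5-dimethoxyphenyl, and it shows that this exchange, which brings in a hydrogen-bond donor, does not move the number beyond the scatter. One value in the set remains a limit of the assay and not a number, that of compound 1: the limit of > 20000 nM in this assay, at which 1 of the 4 values shown sits.

Going by these compounds, whether an amine or a carboxylic acid on the 4-position of the entering phenyl ring would move the number beyond the scatter stays open. The same holds for a longer chain in place of benzyloxy on this carbon.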